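Replacing Allyl by 4-Bromophenyl on the Double-Bonded Nitrogen

A few compounds are considered here, and "the series" means these few. Any claim that something is new, unique, unknown or untested is made for them only; others in the source may bear on it.

Compound 2 `C=CC/N=C1\S/C(=C\c2ccc(OC)cc2)C(=O)N1C` stands at a limit: in an ADME assay on TERT-RPE1 cells (Homo sapiens) for cytotoxicity, read by MTT assay, with a stated time of 72 h (on this read-out lower numbers stand for stronger inhibition and higher numbers for weaker inhibition), compound 2 gives > 100000 nM. Compound 1 `COc1ccc(/C=C2\S/C(=N\c3ccccc3)N(C)C2=O)cc1` likewise stands at a limit, giving > 100000 nM in this assay. Going by the values given here, the only measured step, a step that the two limits leave unreadable from compound 1 to compound 2, is therefore unreadable, as both values rest on (the limit of > 100000 nM in this assay, at which 2 of the 2 values shown sit). Compound 3 `COc1ccc(/C=C2\S/C(=N\c3ccc(Br)cc3)N(C)C2=O)cc1` differs from compound 2 by 4-bromophenyl in place of allyl on a double-bonded nitrogen. Among the compounds with values here, no measured step can size this change, so the expected step in this assay is a number no higher from compound 2 to compound 3 (the limit leaves the size open), most likely ending once more at a limit. Compound 3 is expected to give about 100000 nM, between 40000 nM and 250000 nM.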

Compound 3, half-maximal inhibitory concentration: > 100000 nM
Compound 3 was reported as a limit; the forecaster's own chance of this, stated with the estimate: 80%; the middle value sits exactly at the limit.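

No new step can be read among compound 1, compound 2 and compound 3 in this assay, as all three stand at a limit: (the limit of > 100000 nM in this assay, at which 3 of the 3 values shown sit). The compounds shown leave open whether any of these changes alters cytotoxicity at all, and by how much.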